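A Halogen Exchange on the Fused Aromatic Ring

The source may hold more compounds than are shown below. What is called first, only, known or untested is meant among the compounds shown, and "the series" means these compounds.

Measured compounds in a functional assay on THP-1 cells (Homo sapiens) for inhibition, read by sulforhodamine B assay, with a stated time of 48 h, tested at 50 uM; a lower number here means less inhibition of growth, a higher number more inhibition of growth at the concentration tested:
compound 1, `COc1ccc2c(c1)C(=O)C(=O)N2CCCCCn1cc(COc2cc(=O)oc3ccccc23)nn1`: 30%
compound 2, `O=C1C(=O)N(CCCCCn2cc(COc3cc(=O)oc4ccccc34)nn2)c2ccc([N+](=O)[O-])cc21`: 37%
compound 3, `O=C1C(=O)N(CCCCCn2cc(COc3cc(=O)oc4ccccc34)nn2)c2ccc(I)cc21`: 45%

Compound 3 shows the highest of the three numbers in this assay. Its nearest neighbour is compound 2, which sits a number 8 percentage points higher from compound 2 to compound 3 (within the scatter); the furthest is compound 1, separated by a number 15 percentage points higher from compound 1 to compound 3 (beyond the scatter). Compound 3 is thus clearly apart from compound 1 but not from compound 2.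

Compound 4, `O=C1C(=O)N(CCCCCn2cc(COc3cc(=O)oc4ccccc34)nn2)c2ccc(Cl)cc21`, has not been measured. It differs from compound 3 in one place: chloro in place of iodo on an aromatic carbon.

Among the measured compounds shown here, two measured steps bear on this change, since both end at compound 3 and both replace a group at the same aromatic carbon: the step of a number 15 percentage points higher from compound 1 to compound 3 (beyond the scatter) and the step of a number 8 percentage points higher from compound 2 to compound 3 (within the scatter). For the measured compounds named here, one lies beyond the scatter, the other within it, so the substituent at that carbon can matter, but no chloro compound has been measured. As chloro and iodo are both halogens, the step of a number 5 percentage points lower from compound 3 to compound 4 (within the scatter) is expected to stay within the scatter, with a slight leaning downward. Compound 4 is therefore estimated at 40%, with a range from 28% to 52% in this assay.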

Compound 4, percent growth inhibition at one concentration: 59%
For compound 4 the middle estimate is 19 percentage points below the measured one; the whole stated range lies below it.
By their numbers in this assay, from the lowest: compounds 1, 2 and 3 (each within the scatter of the next, the first and the last beyond it); then compound 4.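

Replacing iodo with chloro on this aromatic carbon gave a number 14 percentage points higher from compound 3 to compound 4 (beyond the scatter) in this assay, even though both groups are single halogen atoms with no hydrogen-bond donors or acceptors, so at this carbon one halogen cannot be taken as a stand-in for the other. Compound 4 is also clearly apart from the nitro and methoxy compounds, with a number 22 percentage points higher from compound 2 to compound 4 (beyond the scatter) and a number 29 percentage points higher from compound 1 to compound 4 (beyond the scatter) in the same assay, which makes it the highest of the four, whereas the iodo compound could be separated only from the methoxy compound and not from the nitro compound. The data offered here give no measured explanation for the difference between chloro and iodo.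

The compounds shown leave open whether fluoro or bromo at this carbon would read nearer to chloro or to iodo, and how an amine or a carboxylic acid would fare there. They also leave open whether the chloro result would hold with a longer chain in place of the present linker, or at other concentrations in this cell assay.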